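Aryl ether series: cyano to 2-methylphenyl at the terminal ring

The compounds below may be only part of what the source reports. "The series", "measured", "known", "first", "only" and "open" are said of these compounds alone.

Going by the values given here, compound 2 `N#Cc1ccc(Oc2cccc(COc3ccccc3CCC(=O)OCCCOP(=O)(O)OC[C@H](N)C(=O)O)c2)cc1` gives 0.041 in an assay on cells for activation of probable G-protein coupled receptor 34 (Mus musculus), with a stated time of 1 h (a lower number here means a smaller maximal response, a higher number a larger maximal response), the lowest of the two numbers so far; the nearest is compound 1 `CCc1ccc(Oc2cccc(COc3ccccc3CCC(=O)OCCCOP(=O)(O)OC[C@H](N)C(=O)O)c2)cc1` with 0.42. Among the compounds with values here, the only measured step that bears on the new change is a number 0.38 lower from compound 1 to compound 2 (beyond the scatter), a large drop beyond the scatter, which shows the cyano group to be the weaker substituent of the two at this position.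

Compound 3 `Cc1ccccc1-c1ccc(Oc2cccc(COc3ccccc3CCC(=O)OCCCOP(=O)(O)OC[C@H](N)C(=O)O)c2)cc1` replaces that group: 2-methylphenyl in place of cyano on an aromatic carbon. Within the data shown here, since the cyano group leaves and a carbon-only aromatic group enters, the direction of the step from compound 2 is expected to reverse the earlier loss, and a rise well beyond the scatter is expected, roughly back to the level of compound 1 and possibly above it, though no measured step tells how a larger ring behaves here. Compound 3 is therefore estimated at 0.5 with a range of 0.2 to 0.85; this estimate means a step of a number 0.46 higher from compound 2 to compound 3 (beyond the scatter).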

Compound 3, intrinsic activity: the largest response reached, as a fraction of the reference agonist's: 0.94
Compound 3: middle estimate off by 0.44, on the low side, and the stated range ends below it.
By their numbers in this assay, from the lowest: compound 2; then compound 1; then compound 3.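

In this assay, this aromatic carbon accepts a much larger group than ethyl or cyano: 2-methylphenyl in place of cyano gives a number 0.90 higher from compound 2 to compound 3 (beyond the scatter), a step that more than reverses the loss seen with cyano. The same group also improves on ethyl, with a number 0.52 higher from compound 1 to compound 3 (beyond the scatter), so the maximal response at this position is not capped at the level of compound 1, and compound 3 is the highest of the three. Nothing measured on these compounds accounts for the rise.

The compounds shown do not separate the contribution of the added ring from that of its methyl group, and a plain phenyl ring would address that. Going by these compounds, how a pyridine ring, a longer alkyl chain such as butyl, an amine or a carboxylic acid behaves at this carbon remains open.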